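The compounds below may be only part of what the source reports. "The series", "measured", "known", "first", "only" and "open" are said of these compounds alone.

Compound 1 `Cc1cc(Cl)ccc1-c1n[nH]c(-c2ccccc2)n1` gives 4 mg/kg in a functional assay on the whole organism (Cricetulus griseus) with Cricetinae gen. sp. as the target; on this read-out higher numbers stand for an effect only at larger amounts of compound and lower numbers for an effect already at smaller amounts. Compound 2 `Cc1ccc(-c2n[nH]c(-c3ccccc3)n2)c(C)c1` reaches only a limit of the assay in this assay, > 5 mg/kg. The change from compound 1 to compound 2 is methyl in place of chloro on an aromatic carbon, and the step it made is an at least 1.2-fold higher number from compound 1 to compound 2 (0.09 log units; that floor lies within the scatter); that this step is given only as a floor is due to the limit of > 5 mg/kg in this assay, at which 1 of the 3 values shown sits.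

Compound 3 `COc1cccc(-c2n[nH]c(-c3ccc(Cl)cc3C)n2)c1` gives 5 mg/kg in this assay, within the scatter of the value for compound 1. How the core of compound 3 differs from the core of compound 1 is not broken down here.

Compound 4 `COc1cccc(-c2n[nH]c(-c3ccc(C)cc3C)n2)c1` has not yet been measured. It differs from compound 3 by methyl in place of chloro on an aromatic carbon, the same change as that from compound 1 to compound 2, at a place described in the same words. On that basis the expected step is a 1.4-fold higher number from compound 3 to compound 4 (0.15 log units; within the scatter), resting on an at least 1.2-fold higher number from compound 1 to compound 2 (0.09 log units; that floor lies within the scatter). For compound 4 a value of 7 mg/kg is estimated in this assay, lying between 3.5 mg/kg and 14 mg/kg, with a fair chance that only a limit is reported.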

Compound 4, dose for half-maximal effect: 10 mg/kg
Estimate against measurement, compound 4: 1.4-fold (0.15 log units) below; the range from low to high includes it.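

On the core of compound 3, methyl in place of chloro gave a 2.0-fold higher number from compound 3 to compound 4 (0.30 log units; within the scatter) in this assay, so this pair shows no effect of the change that stands clear of the scatter, and it gives no sign that the change behaves differently here than on the core of compound 1. The earlier comparison rests on compound 2, whose value of > 5 mg/kg is a limit of the assay and not a number. The two cores therefore do not show that the change carries over with the same size, and the result fits no firmer reading than this: the same change on two cores in this assay, an at least 1.2-fold higher number (0.09 log units; that floor lies within the scatter) from compound 1 to compound 2 and a 2.0-fold higher number (0.30 log units; within the scatter) from compound 3 to compound 4; the limit leaves it open whether they differ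

The compounds shown leave open what the change does on any further core, and whether it ever gives a step beyond the scatter in this assay. They also leave open how other groups would read at the same place, for an amine, a carboxylic acid or a trifluoromethyl group stands there in none of them.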